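The compounds below may be only part of what the source reports. "The series", "measured", "known", "first", "only" and "open" are said of these compounds alone.

Measured in an in vitro ADME assay on microsomes from liver (Homo sapiens) for metabolic stability, in the presence of a further agent that is not named here; on this read-out higher numbers stand for fast clearance and lower numbers for slow clearance:
- Compound 1 `CC(C)(O)CCNC(=O)c1cc2cc(C#N)ccc2n1Cc1cccc(OC(F)(F)F)c1`: < 6 mL.min-1.g-1 (a limit, not a number)
- Compound 2 `N#Cc1ccc2c(c1)cc(C(=O)NCCC(O)C(F)(F)F)n2Cc1cccc(OC(F)(F)F)c1`: 31 mL.min-1.g-1
- Compound 3 `N#Cc1ccc2c(c1)cc(C(=O)NCCC(O)(C(F)(F)F)C(F)(F)F)n2Cc1cccc(OC(F)(F)F)c1`: 24 mL.min-1.g-1

The two fluorinated members occupy the higher end of the series, and the gap between them is a 1.3-fold lower number from compound 2 to compound 3 (0.11 log units; within the scatter). Compound 3 therefore stands level with compound 2 and clearly apart from compound 1.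

The next structure is compound 4 `N#Cc1ccc2c(c1)cc(C(=O)NCCC1(O)CCC1)n2Cc1cccc(OC(F)(F)F)c1`, reached through (1-hydroxycyclobutyl in place of 2,2,2-trifluoro-1-hydroxy-1-(trifluoromethyl)ethyl on a saturated chain carbon, two bonds along the chain from an amide-type nitrogen). The entering 1-hydroxycyclobutyl holds carbon and oxygen only, so the fluorine of the side chain is lost.

Among the measured compounds shown here, two measured steps bear most directly on this change: an at least 5.1-fold higher number from compound 1 to compound 2 (0.71 log units; beyond the scatter) and an at least 4.0-fold higher number from compound 1 to compound 3 (0.60 log units; beyond the scatter). For the measured compounds named here, both run from the fluorine-free side chain to a fluorinated one, and no compound here goes against that direction. The step from compound 3 to compound 4 runs the opposite way. Compound 1, whose < 6 mL.min-1.g-1 is a limit, is the closest measured comparison. Going by the values given here, no measured compound carries the ring, so the comparison is only approximate.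

A fall beyond the scatter is expected, with the number landing near the low end of the series. The expected step is a 2.7-fold lower number from compound 3 to compound 4 (0.43 log units; beyond the scatter). For compound 4 the estimate is 9 mL.min-1.g-1, with an expected range of 4 mL.min-1.g-1 to 20 mL.min-1.g-1.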

Compound 4, intrinsic clearance in microsomes: < 6 mL.min-1.g-1
Compound 4 gave a limit, no number; the forecaster's own chance of this, stated with the estimate: 35%; middle value at least 1.5-fold (0.17 log units) from the limit.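

Compound 4 returns a limit in this assay, < 6 mL.min-1.g-1, rather than a number. Replacing the fluorinated side chains with 1-hydroxycyclobutyl on the saturated chain carbon gives an at least 4.0-fold lower number from compound 3 to compound 4 (0.60 log units; beyond the scatter) and an at least 5.1-fold lower number from compound 2 to compound 4 (0.71 log units; beyond the scatter), both beyond the scatter, so the fall seen earlier with the open-chain 1-hydroxy-1-methylethyl also holds for a side chain with a four-membered ring of carbon only. Across these four compounds, both fluorine-free side chains sit at the limit and both fluorinated ones give measured numbers, and no compound goes against this pattern.

The step between compound 1 and compound 4 cannot be read, so the two fluorine-free side chains cannot be ranked, because both rest on the same limit: the limit of < 6 mL.min-1.g-1 in this assay, at which 2 of the 4 values shown sit. Also open, going by these compounds, is how this assay would read for a 1-hydroxycyclopentyl group, a side chain with a single fluorine, or an amine in place of the hydroxyl, and whether the pattern would hold for any of them.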